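A few compounds are considered here, and "the series" means these few. Any claim that something is new, unique, unknown or untested is made for them only; others in the source may bear on it.

The measured compounds:
Compound 1 `O=C1Nc2ccc(Cl)cc2/C1=N/NC(=S)N1CCN(c2ccc(Cl)cc2)CC1`, which gives 5390 nM in a functional assay on HCT-116 cells (Homo sapiens) for inhibition, read by MTT assay, with a stated time of 72 h; a lower number here means a stronger inhibitor, a higher number a weaker inhibitor.
Compound 2 `O=C1Nc2ccc(Cl)cc2/C1=N/NC(=S)N1CCN(c2ccc(F)cc2)CC1`, which gives 6350 nM in this assay.

Among the measured compounds shown here, compound 2 has the highest of the two numbers so far, and its only neighbour is compound 1; the step of a 1.2-fold higher number from compound 1 to compound 2 (0.07 log units; within the scatter) keeps the pair within the scatter, so no order between them can be read. Compound 3 `O=C1Nc2ccc(Cl)cc2/C1=N/NC(=S)N1CCN(c2ccccc2[N+](=O)[O-])CC1` has not yet been tested in this assay. It differs from compound 2 in one place: 2-nitrophenyl in place of 4-fluorophenyl on an amine nitrogen in a ring. For the measured compounds named here, the single measured step swaps one halogen for another on the same aromatic ring and therefore bears on the present change only loosely; it shows that a modest alteration of that ring left the number essentially where it was. The move to a 2-nitrophenyl is a larger alteration, and nothing measured here indicates its direction. Compound 3 is therefore expected to give about 6000 nM in this assay, with a range from 2500 nM to 15000 nM. That estimate means a step of a 1.1-fold lower number from compound 2 to compound 3 (0.02 log units; within the scatter), expected to stay within the scatter.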

Compound 3, half-maximal inhibitory concentration: 4570 nM
For compound 3 the middle estimate is 1.3-fold (0.12 log units) above the measured one, within the range that was stated.
By their numbers in this assay, from the lowest: compounds 3, 1 and 2 (each within the scatter of the next).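

In this assay, putting 2-nitrophenyl on the amine nitrogen in the ring gives a 1.4-fold lower number from compound 2 to compound 3 (0.14 log units; within the scatter), and the same group gives a 1.2-fold lower number from compound 1 to compound 3 (0.07 log units; within the scatter) when set against the 4-chlorophenyl of compound 1. The earlier pair showed only one halogen exchanged for another, whereas this change brings in a larger group with hydrogen-bond acceptors that the 4-fluorophenyl does not have, and all three compounds still lie within the scatter of one another, so this position tolerates more than a halogen swap without a readable shift in the number. Nothing available here gives a reason for this outcome, and the three values alone cannot supply one.

On these data alone, all three compounds carry a substituted phenyl on this nitrogen, so it remains open whether a plain phenyl, a benzyl group, a short alkyl chain or a carboxylic acid there would leave the number in the same place. As far as these compounds go, it also remains open whether a 4-nitrophenyl would match the 2-nitrophenyl, and whether any change at this position can move the number beyond the scatter at all.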